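A few compounds are considered here, and "the series" means these few. Any claim that something is new, unique, unknown or untested is made for them only; others in the source may bear on it.

Compound 1, `CCN1C(=O)CCC1(O)c1cccc(C(F)(F)F)c1`: in a functional assay on the whole organism with Mus musculus as the target (on this read-out higher numbers stand for an effect only at larger amounts of compound and lower numbers for an effect already at smaller amounts), compound 1 gives > 100 mg/kg, which is a limit of the assay and not a number.
Compound 2, `CCCN1C(=O)CCC1(O)c1cccc(C(F)(F)F)c1`: in this assay compound 2 gives > 200 mg/kg, again a limit of the assay.
Compound 3, `CC(C)NC(=O)CCC(=O)c1cccc(C(F)(F)F)c1`: in this assay compound 3 gives > 200 mg/kg, also a limit of the assay.

Compound 1 and compound 2 differ by one change, (methyl in place of hydrogen on a saturated chain carbon, two bonds along the chain from an amide-type nitrogen in a ring). Its effect in this assay is a step that the two limits leave unreadable from compound 1 to compound 2, so the step cannot be sized: one value sits at the limit of > 100 mg/kg in this assay, at which 1 of the 3 values shown sits, and the other at the limit of > 200 mg/kg in this assay, at which 2 of the 3 values shown sit.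

Compound 4, `CCC(C)NC(=O)CCC(=O)c1cccc(C(F)(F)F)c1`, has not yet been measured. It relates to compound 3 through (methyl in place of hydrogen on a saturated chain carbon, two bonds along the chain from an amide-type nitrogen). Among the compounds with values here, this is the same kind of change as the one from compound 1 to compound 2, with one difference around the place: in compound 1 the amide-type nitrogen sits in a ring, in compound 3 it does not. How the core of compound 3 differs from the core of compound 1 is not broken down here.

Within the data shown here, since the only measured example of this change is unreadable, the expectation for compound 4 rests mainly on compound 3 itself. Compound 3 gives > 200 mg/kg, a limit of the assay. Compound 4 is therefore expected to behave much like compound 3, with an estimated step that the limit leaves unreadable from compound 3 to compound 4 in this assay. The estimated value for compound 4 is 300 mg/kg, most likely again reported as a limit rather than a number.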

Compound 4, dose for half-maximal effect: > 200 mg/kg
Compound 4 ended at the assay's limit; the forecaster's own chance of this, stated with the estimate: 80%; the middle value is on the limit's open side.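

In this assay compound 3 and compound 4 both stop at a limit of the assay rather than a number, so the step from one to the other cannot be read. The compounds shown leave open whether this assay would give a real number for any of them, and so what the change from isopropyl to sec-butyl does to the effect.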